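Methyl in Place of Iodo: Expecting Compound 4

The compounds below may be only part of what the source reports. "The series", "measured", "known", "first", "only" and "open" are said of these compounds alone.

Compound 3 `Nc1ccc(-c2nc3ccccc3s2)cc1I` gives in a functional assay on MCF7 cells (Homo sapiens) for cytotoxicity (a higher number here means a weaker inhibitor, a lower number a stronger inhibitor), only a limit, < 1 nM, so its true value is not known. That is the limit of < 1 nM in this assay, at which 1 of the 3 values shown sits, and the strongest reading the assay can report. Compound 1 `Nc1ccc(-c2nc3cc(O)ccc3s2)cc1` also returns a limit, > 100000 nM, at the other end of the range. Compound 2 `CC(=O)Nc1ccc(-c2nc3cc(O)ccc3s2)cc1Cl`, carrying acetylamino and chloro, gives 31000 nM. Compound 4 `Cc1cc(-c2nc3ccccc3s2)ccc1N` differs from compound 3 by methyl in place of iodo on an aromatic carbon. Going by the values given here, no measured pair isolates this change, so the size of the step is open. The expected step of an at least 50-fold higher number from compound 3 to compound 4 (1.69 log units; beyond the scatter) is a loss toward weaker inhibition beyond the scatter, since compound 3 sits at the limit of < 1 nM in this assay, at which 1 of the 3 values shown sits, and can only move upward. Compound 4 is estimated at 50 nM, within 1 nM to 3000 nM.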

Compound 4, half-maximal inhibitory concentration: < 1 nM
Compound 4: a limit, no number; the forecaster's own chance of this, stated with the estimate: 20%; middle value at least 50-fold (1.69 log units) away from the limit.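

Going by these compounds alone, compound 3 and compound 4 each return only a limit in this assay, so no step between them can be read. The compounds shown leave open what methyl in place of iodo does to the true value.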